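Methoxy for fluoro: from compound 3 to compound 4

The source may report more compounds than this note shows. Statements on the series, on what has been measured and on what is new or still open speak of the compounds shown alone.

In an ADME assay on the whole organism (Rattus norvegicus, strain Sprague-Dawley) for pharmacokinetics, using cassette dosing, at a dose of 1 mg/kg by the oral route (on this read-out higher numbers stand for higher oral bioavailability and lower numbers for lower oral bioavailability), compound 1 `O=C(c1cc(-c2ccc(=O)[nH]c2)on1)N1CCC(Cc2ccc(Cl)cc2)CC1` gives 9.3%, compound 2 `O=C(Nc1ccc2[nH]c(=O)oc2c1)C(=O)N1CCN(c2ccc(F)cc2)CC1` gives 39.3% and compound 3 `O=C(Nc1ccc2[nH]c(=O)oc2c1)C(=O)N1CCN(c2ccc(F)c(F)c2)CC1` gives 13%. Compound 3 thus lies within the scatter of compound 1 and beyond the scatter from compound 2. Compound 4 `COc1ccc(N2CCN(C(=O)C(=O)Nc3ccc4[nH]c(=O)oc4c3)CC2)cc1F` differs from compound 3 by methoxy in place of fluoro on an aromatic carbon: methoxy in place of fluoro, 3,4-difluorophenyl to 3-fluoro-4-methoxyphenyl. Going by the values given here, the one measured step bearing on it is a number 26.3 percentage points lower from compound 2 to compound 3 (beyond the scatter), a modest change on the same aromatic ring, but for a different substitution. No methoxy comparison exists, so no step beyond the scatter is expected, though that step argues for a wide range. The expected change is a number 3 percentage points higher from compound 3 to compound 4 (within the scatter). The estimate for compound 4 is 16%, with a range of 6% to 35%.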

Compound 4, oral bioavailability: 0.6%
Beside the measured number, compound 4's estimate is 15.4 percentage points above it; the whole stated range lies above it.
By their numbers in this assay, from the lowest: compounds 4, 1 and 3 (each within the scatter of the next, the first and the last beyond it); then compound 2.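

Methoxy in place of fluoro, para to a large group, gives a number 12.4 percentage points lower from compound 3 to compound 4 (beyond the scatter) in this assay and so shows that this site still moves the read-out once the ring carries two fluoro groups. Against the 4-fluorophenyl compound, the 3-fluoro-4-methoxyphenyl group gives a number 38.7 percentage points lower from compound 2 to compound 4 (beyond the scatter) on the same read-out, and every step measured on this ring so far is downward. Nothing at hand accounts for these drops.

From the compounds shown here alone, whether methoxy lowers the number without the neighbouring fluoro group remains open. So does the outcome with an amine, a carboxylic acid or a longer alkoxy chain at this site.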